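The source may report more compounds than this note shows. Statements on the series, on what has been measured and on what is new or still open speak of the compounds shown alone.

In a functional assay on NCI-H460 cells (Homo sapiens) for inhibition, read by MTT assay, with a stated time of 72 h (a lower number here means a stronger inhibitor of growth, a higher number a weaker inhibitor of growth), compound 2 `COc1ccc(CNC(=O)/C(C#N)=C/c2ccc(Cl)o2)cc1` gives 15000 nM, the lowest of the two numbers shown here. Compound 1 `N#C/C(=C\c1c(F)c(F)c(F)c(F)c1F)C(=O)c1c[nH]c2ccccc12` gives 35000 nM in this assay, a higher number that lies beyond the usual scatter. Compound 3 `COc1ccc(CNC(=O)/C(C#N)=C/c2ccc(-c3ccccc3)o2)cc1` reaches only the limit > 100000 nM in this assay, so it supplies no number. Where phenyl replaces chloro on an aromatic carbon, the number rises by an at least 6.6-fold higher number from compound 2 to compound 3 (0.82 log units; beyond the scatter), as the limit of > 100000 nM in this assay, at which 1 of the 3 values shown sits, shows.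

Compound 4 `COc1ccc(CNC(=O)/C(C#N)=C/c2ccc(Cl)cc2)cc1` differs from compound 2 in one place: 4-chlorophenyl in place of 5-chlorofuran-2-yl on a double-bonded chain carbon bound to a double-bonded chain carbon. The chlorine stays, while the five-membered ring with one oxygen gives way to a six-membered ring of carbon only. Within the data shown here, no measured step swaps one aromatic ring for another, so the only step available, the one that added a phenyl and pushed the number to the limit, bears on this change only loosely. In this assay the expected step is a 1.7-fold higher number from compound 2 to compound 4 (0.22 log units; within the scatter), a small rise that may not exceed the scatter. Compound 4 is therefore estimated at about 25000 nM in this assay, between 8000 nM and 80000 nM.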

Compound 4, concentration for 50% growth inhibition: 14000 nM
Estimate against measurement, compound 4: 1.8-fold (0.25 log units) above; low and high end bracket the measured number.
By their numbers in this assay, from the lowest: compounds 4 and 2 (each within the scatter of the next); then compound 1. At a limit, above all of these: compound 3.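

Exchanging 5-chlorofuran-2-yl for 4-chlorophenyl gives a 1.1-fold lower number from compound 2 to compound 4 (0.03 log units; within the scatter) in this assay and so leaves growth inhibition unchanged within the scatter. For these two compounds the five-membered ring with one oxygen is not required at this place, as a six-membered ring of carbon only does as well while the chlorine stays. The ring carrying the chlorine can therefore change without shifting the number, whereas the step to compound 3, which replaced the chlorine itself with phenyl, did shift it.

From the compounds shown here alone, compound 3 stands at a limit and not at a number, so the true size of its step stays unknown: the limit of > 100000 nM in this assay, at which 1 of the 4 values shown sits. Going by these compounds, whether an amine or a carboxylic acid in place of the chlorine on the six-membered ring would keep this level of growth inhibition also remains open.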